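Replacing a Vinyl Terminus with Hydroxymethyl on a Side Chain

The source may report more compounds than this note shows. Statements on the series, on what has been measured and on what is new or still open speak of the compounds shown alone.

Compound 1 `C=CCCn1c(=O)c2[nH]cnc2n(CCC)c1=O`: 60 nM
Compound 2 `CCCn1c(=O)n(CCC(N)=O)c(=O)c2[nH]cnc21`: 31500 nM

In an assay on Cerebral cortex for binding affinity to adenosine receptor A1 (Cavia porcellus), read by radioligand binding (a higher number here means a weaker inhibitor, a lower number a stronger inhibitor), compound 1 gives 60 nM, the lowest of the two numbers shown. Going by the values given here, the nearest measured neighbour is compound 2, which gives 31500 nM; the step between them, a 530-fold higher number from compound 1 to compound 2 (2.72 log units; beyond the scatter), is the only measured step that bears on what follows, and it was large.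

Compound 3 `CCCn1c(=O)n(CCCO)c(=O)c2[nH]cnc21` is not yet measured. It differs from compound 1 in one place: hydroxymethyl in place of vinyl on a saturated chain carbon, two bonds along the chain from an aromatic nitrogen. The same place was changed in the step from compound 1 to compound 2, where carbamoyl took the place of vinyl, and the number rose sharply. A rise is therefore expected for compound 3 as well, although hydroxymethyl is not carbamoyl and the size cannot be read directly; the step is estimated as a 33-fold higher number from compound 1 to compound 3 (1.52 log units; beyond the scatter). Compound 3 is expected to give about 2000 nM, in the range 400 nM to 10000 nM.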

Compound 3, inhibition constant: 12000 nM
Estimate against measurement, compound 3: 6.0-fold (0.78 log units) below; the whole stated range lies below it.
By their numbers in this assay, from the lowest: compound 1; then compound 3; then compound 2.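

In this assay, the new result shows that the sharp rise at this position is not peculiar to carbamoyl: hydroxymethyl in place of vinyl also gives a 200-fold higher number from compound 1 to compound 3 (2.30 log units; beyond the scatter) and so stays far from compound 1. The two replacements are not equivalent, however, with a 2.6-fold lower number from compound 2 to compound 3 (0.42 log units; beyond the scatter) as a modest step that is still beyond the scatter. Nothing available gives a reason for either step.

The compounds shown leave open whether an amine or a carboxylic acid at the end of this chain would fall nearer to compound 1 or to compound 2. They also leave open whether a longer chain ending in hydroxyl would differ from the 3-hydroxypropyl group of compound 3, or whether a saturated propyl or butyl chain would keep the low number of compound 1.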